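A few compounds are considered here, and "the series" means these few. Any claim that something is new, unique, unknown or untested is made for them only; others in the source may bear on it.

Compound 2 `Cc1ccc2nc(-c3ccccn3)c(Nc3ccc4c(c3)OCCO4)n2c1` and compound 1 `c1ccc(-c2nc3ccccn3c2Nc2ccc3c(c2)OCCO3)nc1` share one core and differ in a single place, (hydrogen in place of methyl on an aromatic carbon). In an ADME assay on THP-1 cells (Homo sapiens) for cytotoxicity (a higher number here means that more compound is tolerated, a lower number that less compound is tolerated), compound 2 gives 16000 nM, and compound 1 gives 25600 nM; the step of a 1.6-fold higher number from compound 2 to compound 1 (0.20 log units; within the scatter) is small. Compound 3 `Cc1ccn2c(NC3CCCC3)c(-c3ccc(N(C)C)cc3)nc2c1` has a different core; how the two cores differ is not broken down here. In this assay compound 3 gives only > 50000 nM, which is a limit of the assay and not a number (the limit of > 50000 nM in this assay, at which 1 of the 3 values shown sits). Compound 4 `CN(C)c1ccc(-c2nc3ccccn3c2NC2CCCC2)cc1` arises from compound 3 by the same kind of change, (hydrogen in place of methyl on an aromatic carbon); the place is not identical, since in compound 2 it sits two atoms from the ring nitrogen and in compound 3 opposite the ring nitrogen. Since the measured step of a 1.6-fold higher number from compound 2 to compound 1 (0.20 log units; within the scatter) lies within the scatter, the step from compound 3 to compound 4 is expected to be a step that the limit leaves unreadable from compound 3 to compound 4. Compound 4 is therefore expected to give about 60000 nM in this assay, between 25000 nM and 150000 nM, most likely reported again as a limit.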

Compound 4, half-maximal cytotoxic concentration: > 50000 nM
Compound 4 was reported as a limit; the forecaster's own chance of this, stated with the estimate: 70%; the middle value is on the limit's open side.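

Compound 3 and compound 4 both sit at a limit of this assay, not at a number, so no step between them can be read: the limit of > 50000 nM in this assay, at which 2 of the 4 values shown sit.

The compounds shown leave open what hydrogen in place of methyl does on the core of compound 3 in this assay.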